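Nitro in Place of Methyl on the Shared Core

The compounds below may be only part of what the source reports. "The series", "measured", "known", "first", "only" and "open" are said of these compounds alone.

Measured so far:
compound 1, `FC(F)(F)c1ccc(OC(CCn2ccnc2)c2ccccc2)cc1`: 71000 nM
compound 2, `Cc1ccc(OC(CCn2ccnc2)c2ccccc2)cc1`: 95900 nM

In a functional assay on K562 cells (Homo sapiens) for cytotoxicity (on this read-out higher numbers stand for lower toxicity in this test and lower numbers for higher toxicity in this test), compound 1 gives 71000 nM and compound 2 gives 95900 nM. For the measured compounds named here, compound 2 holds the higher of the two numbers, yet the single measured step, a 1.4-fold higher number from compound 1 to compound 2 (0.13 log units; within the scatter), stays within the scatter, so the two compounds cannot be set apart on this read-out; both sit at high concentrations, which here means low toxicity.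

Compound 3, `O=[N+]([O-])c1ccc(OC(CCn2ccnc2)c2ccccc2)cc1`, differs from compound 2 by one change: nitro in place of methyl on an aromatic carbon. Going by the values given here, no measured step exchanges methyl for nitro, so nothing bears on it directly. Among the compounds with values here, the one step known shows that exchanging one group for another on that aromatic carbon of the shared core left the number unchanged within the scatter. On that footing the expected step is a 1.1-fold lower number from compound 2 to compound 3 (0.03 log units; within the scatter), that is, no change beyond the scatter in either direction, with wide uncertainty since the nitro group is new to this series. Compound 3 is therefore estimated at 90000 nM, with a range from 40000 nM to 200000 nM.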

Compound 3, half-maximal cytotoxic concentration: 102000 nM
For compound 3 the middle estimate is 1.1-fold (0.05 log units) below the measured one; the measured number falls inside the stated range.
By their numbers in this assay, from the lowest: compounds 1, 2 and 3 (each within the scatter of the next).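

In this assay, nitro in place of methyl on the aromatic carbon para to a large group gives a 1.1-fold higher number from compound 2 to compound 3 (0.03 log units; within the scatter), and nitro in place of trifluoromethyl on that same carbon gives a 1.4-fold higher number from compound 1 to compound 3 (0.16 log units; within the scatter), so neither exchange moves the number beyond the scatter. For the compounds shown here, the earlier pair showed this for only two groups; this position has now carried three, and nitro, which brings three heavy atoms and two hydrogen-bond acceptors where methyl has one heavy atom and no acceptor, still leaves compound 1, compound 2 and compound 3 within the scatter of one another. Nothing available offers an explanation for this flat result.

The compounds shown leave open whether an amine or a carboxylic acid on this aromatic carbon, both of which can also give up a hydrogen in a hydrogen bond, or a longer carbon chain there, would stay within the scatter or shift the number. They also leave open whether any change at this position can bring the number down from these high concentrations, which here stand for low toxicity.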